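The source may hold more compounds than are shown below. What is called first, only, known or untested is meant among the compounds shown, and "the series" means these compounds.

In a functional assay on HCT-116 cells (Homo sapiens), read by MTT assay, with a stated time of 72 h (on this read-out lower numbers stand for stronger inhibition and higher numbers for weaker inhibition), the measured compounds are:

- compound 1 `CSc1ncnc2c1c(-c1ccoc1)cn2[C@@H]1O[C@H](CO)[C@@H](O)[C@H]1O`: 100 nM
- compound 2 `CSc1ncnc2c1c(-c1cccs1)cn2[C@@H]1O[C@H](CO)[C@@H](O)[C@H]1O`: > 20000 nM

Compound 2 gives no number, only a limit, and stands at the limit of > 20000 nM in this assay, at which 1 of the 2 values shown sits.

Compound 3 `CSc1ncnc2c1c(-c1ccsc1)cn2[C@@H]1O[C@H](CO)[C@@H](O)[C@H]1O` has thiophen-3-yl in place of the thiophen-2-yl of compound 2 on an aromatic carbon (thiophen-3-yl in place of thiophen-2-yl on an aromatic carbon). The two have the same atoms, joined differently.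

Among the compounds with values here, the one measured step that bears on this is large: an at least 200-fold higher number from compound 1 to compound 2 (2.30 log units; beyond the scatter). That step changed both the ring type and its point of attachment, so the data cannot separate the two changes. Compound 3 keeps the thiophene of compound 2 but, like the furan-3-yl of compound 1, is attached through its 3-position. A partial return towards stronger inhibition is therefore expected in this assay, though a limit remains possible.

The expected change is an at least 20-fold lower number from compound 2 to compound 3 (1.30 log units; beyond the scatter).

For compound 3, the estimated value is 1000 nM, with an expected range of 100 nM to 15000 nM.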

Compound 3, half-maximal inhibitory concentration: > 20000 nM
Compound 3: only a limit was reported (the forecaster's own chance of this, stated with the estimate: 30%); middle value at least 20-fold (1.30 log units) from the limit.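

Attachment through the 3-position is not enough to keep inhibition at this position: in this assay, replacing furan-3-yl with thiophen-3-yl gives an at least 200-fold higher number from compound 1 to compound 3 (2.30 log units; beyond the scatter). This pair shares its point of attachment and differs only in the ring, so the earlier loss cannot be blamed on attachment alone, and exchanging the furan for a thiophene is enough to produce a large loss here. The step between the two thiophenes cannot be read, as both compounds give only limits, so any difference between them stays hidden: the limit of > 20000 nM in this assay, at which 2 of the 3 values shown sit.

Still open, on these data alone, is whether furan-2-yl would behave like furan-3-yl, which would show if attachment matters within the furans. It is also unknown whether other rings, such as pyrrol-3-yl or phenyl, would fall on the side of the furan or of the thiophenes.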